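A Longer Side Chain on the Shared Core

The source may report more compounds than this note shows. Statements on the series, on what has been measured and on what is new or still open speak of the compounds shown alone.

Of the two compounds measured in a toxicity assay on C8166 cells (Homo sapiens) for cytotoxicity, read by MTT assay, with a stated time of 72 h (on this read-out lower numbers stand for higher toxicity in this test and higher numbers for lower toxicity in this test), compound 3 `C[C@H](CO)Nc1nc(C(=O)NCc2ccc(F)cc2)c(O)c2ncccc12` gives 69000 nM and compound 1 `C[C@@H](CO)Nc1nc(C(=O)NCc2ccc(F)cc2)c(O)c2ncccc12` gives 107000 nM; the step of a 1.6-fold lower number from compound 1 to compound 3 (0.19 log units; within the scatter) is within the scatter, so the two stand together. Among the compounds with values here, the only measured step rests on (the fact that compounds 1 and 3 differ only in the configuration as drawn). Compound 2 `C[C@@H](Nc1c(C(=O)NCc2ccc(F)cc2)nc(Br)c2cccnc12)c1ccccc1` gives "not determined" (no result reported) in this assay. Compound 4 `O=CNCCCCCCNc1nc(C(=O)NCc2ccc(F)cc2)c(O)c2ncccc12` differs from compound 3 by 6-(formylamino)hexyl in place of 1-(hydroxymethyl)ethyl on a nitrogen on an aromatic ring. The measured step from compound 1 to compound 3 concerns configuration alone, not a replacement of a chain, so it offers little guidance here, and no step beyond the scatter is expected; the estimated step of a 1.0-fold higher number from compound 3 to compound 4 (0.01 log units; within the scatter) is small. Compound 4 is expected to give 70000 nM, with a range from 25000 nM to 200000 nM.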

Compound 4, half-maximal cytotoxic concentration: 199000 nM
For compound 4 the middle estimate is 2.8-fold (0.45 log units) below the measured one; low and high end bracket the measured number.
By their numbers in this assay, from the lowest: compounds 3, 1 and 4 (each within the scatter of the next, the first and the last beyond it).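

In this assay, 6-(formylamino)hexyl in place of 1-(hydroxymethyl)ethyl on this nitrogen gives a 2.9-fold higher number from compound 3 to compound 4 (0.46 log units; beyond the scatter) but only a 1.9-fold higher number from compound 1 to compound 4 (0.27 log units; within the scatter) when read against the other drawn configuration. Within the data shown here, this is the first change of the chain itself, and it moves the number beyond the scatter only against compound 3. Nothing shown here explains this step. The compounds shown leave open whether the chain length or the formylamino end matters more, and how a shorter chain or one ending in an amine or a carboxylic acid would read.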